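The source may hold more compounds than are shown below. What is called first, only, known or untested is meant among the compounds shown, and "the series" means these compounds.

Measured so far:

Compound 1, `COc1cc(C)cc(-c2nn(CC#N)cc2-c2ccc(-c3cccc(C(C)=O)c3)nc2)c1`, in a functional assay on U-251 cells (Homo sapiens) for cytotoxicity, read by sulforhodamine B assay, with a stated time of 48 h, tested at 0.001 uM (on this read-out higher numbers stand for a weaker effect at the one concentration tested and lower numbers for a stronger effect), compound 1 gives 98%.
Compound 2, `Cc1cc(O)cc(-c2nn(CC#N)cc2-c2ccnc(-c3ccc(Oc4ccccc4)cc3)c2)c1`, in this assay compound 2 gives 97%.
Compound 3, `COc1cc(C)cc(-c2nn(CC#N)cc2-c2ccnc(-c3ccc(N(C)C)cc3)c2)c1`, in this assay compound 3 gives 94%.

All three numbers in this assay sit close together, and each lies within the scatter of the other two, so none of the three can be set apart from the rest. Compound 3 has the lowest of the three numbers, but the gap to compound 2 and the gap to compound 1 both fall inside the scatter, so nothing more than that is to be read from it.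

The next compound, compound 4, `Cc1cc(O)cc(-c2nn(CC#N)cc2-c2ccnc(-c3ccc(N(C)C)cc3)c2)c1`, differs from compound 3 in one place: hydrogen in place of methyl on an oxygen on an aromatic ring. Compound 2 already carries the hydroxy in the same place on a different tail and gives a number of the same kind in this assay. For the measured compounds named here, no step between two measured compounds in this assay tells what this change does on its own. The expected step of a number 2 percentage points higher from compound 3 to compound 4 (within the scatter) is therefore no more than the scatter, in no set direction. For compound 4 in this assay the estimate is 96%, with a range from 88% to 101%.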

Compound 4, a percentage reported as activity, at one concentration (the size of the read-out at that concentration, not a potency): 101%
Estimate against measurement, compound 4: 5 percentage points below, and the stated range covers the measured number.
By their numbers in this assay, from the lowest: compounds 3, 2, 1 and 4 (each within the scatter of the next).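

In this assay, for the compounds shown here, methoxy to hydroxy on the 3-methoxy-5-methylphenyl gives a number 7 percentage points higher from compound 3 to compound 4 (within the scatter) and is the first direct reading of this change, which cannot be told from the scatter at this one concentration. With the hydroxy kept, dimethylamino in place of phenoxy on an aromatic carbon gives a number 4 percentage points higher from compound 2 to compound 4 (within the scatter) and also cannot be told from the scatter, so neither change sets a compound apart here. No measurement at hand bears on why these numbers stay together.

As far as these compounds go, whether an amine or a carboxylic acid in place of the hydroxy, or a longer chain such as ethoxy on the oxygen, would move the number beyond the scatter stays open. Also open, from the compounds shown here alone, is whether the methoxy to hydroxy change would separate these compounds at higher concentrations.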